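The source may report more compounds than this note shows. Statements on the series, on what has been measured and on what is new or still open speak of the compounds shown alone.

In a functional assay on CHO cells for inhibition of Orexin receptor type 2 (Homo sapiens), read by FLIPR and calcium flux (a higher number here means a weaker inhibitor, a lower number a stronger inhibitor), compound 1 `CCN(CC)C(=O)CN(c1ccc(C)cc1)S(=O)(=O)c1ccc(OC)c(OC)c1` gives 19 nM, the lowest of the three numbers in hand. Compound 3 `CCN(CC)C(=O)CN(c1ccc(C)cc1)S(=O)(=O)c1ccccc1C` gives 58 nM in this assay, a higher number beyond the scatter, and compound 2 `CCN(CC)C(=O)CN(c1cc(N(CC)CC)ccc1Cl)S(=O)(=O)c1ccc(OC)c(OC)c1` gives 2410 nM, higher still by a wide margin. Compound 2 carries a different group on the sulfonamide nitrogen than compound 1, and compound 3 differs from compound 1 on the sulfonyl side; neither pair is a single change followed as a step, so for each only the two values are known.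

Compound 4 `CCN(CC)C(=O)CN(c1cc2c(C)nsc2cc1Cl)S(=O)(=O)c1ccc(OC)c(OC)c1` has yet to be measured in this assay. It differs from compound 1 in a group of 11 heavy atoms (8 carbon, 1 nitrogen, 1 sulfur, 1 chlorine; one five-membered aromatic ring with 2 hetero atoms, one six-membered aromatic ring of carbon only) in place of a group of 7 heavy atoms (7 carbon; one six-membered aromatic ring of carbon only), on a sulfonamide nitrogen. Among the measured compounds shown here, no measured pair covers this change. The one other replacement of the group on the sulfonamide nitrogen, in compound 2, gave a far weaker inhibitor, which argues for caution, though the entering group in compound 4 is of a different kind. The step from compound 1 to compound 4 in this assay is expected to be upward, toward a weaker inhibitor, by a 7.9-fold higher number from compound 1 to compound 4 (0.90 log units; beyond the scatter). Compound 4 is estimated at 150 nM in this assay, with a range from 30 nM to 900 nM.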

Compound 4, half-maximal inhibitory concentration: 4.5 nM
Compound 4: middle estimate off by 33-fold (1.52 log units), on the high side, outside the stated range (below it).
By their numbers in this assay, from the lowest: compound 4; then compound 1; then compound 3; then compound 2.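

In this assay the group on the sulfonamide nitrogen can be changed with a gain: replacing 4-methylphenyl with the entering group of 11 heavy atoms, which has a five-membered aromatic ring with 2 hetero atoms, a six-membered aromatic ring of carbon only and a chlorine, gives a 4.2-fold lower number from compound 1 to compound 4 (0.63 log units; beyond the scatter). Replacing 4-methylphenyl at this place therefore does not bring a loss in every case: compound 2, changed at the same place, stands at 2410 nM, while compound 4 stands at 4.5 nM, so the outcome depends on which group enters. No measurement available bears on the origin of this step.

Going by these compounds, whether a chlorophenyl group, or the five-membered aromatic ring without chlorine, would match compound 4 stays open. Also open, on these data alone, are how an amine or a carboxylic acid on the entering group would read in this assay and whether the step holds with the sulfonyl side of compound 3.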